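Swapping Piperazine for Imidazole on an Amide Side Chain

A few compounds are considered here, and "the series" means these few. Any claim that something is new, unique, unknown or untested is made for them only; others in the source may bear on it.

Compound 1 `CN(C)CC(=O)N1CCC(NS(=O)(=O)c2cc(S(=O)(=O)c3ccccc3)ccc2C(F)(F)F)CC1`: 300 nM
Compound 2 `O=C(CN1CCNCC1)N1CCC(NS(=O)(=O)c2cc(S(=O)(=O)c3ccccc3)ccc2C(F)(F)F)CC1`: 140 nM

Both numbers come from an assay on isolated protein for binding affinity to secreted frizzled-related protein 1 (Homo sapiens), read by fluorescence; a higher number here means a weaker inhibitor, a lower number a stronger inhibitor. For the measured compounds named here, compound 2 stands at the lower of the two, and the single measured step, a 2.1-fold lower number from compound 1 to compound 2 (0.33 log units; beyond the scatter), is modest. Compound 3 `O=C(Cn1ccnc1)N1CCC(NS(=O)(=O)c2cc(S(=O)(=O)c3ccccc3)ccc2C(F)(F)F)CC1` is not yet measured; its change is 1H-imidazol-1-yl in place of piperazin-1-yl on a saturated chain carbon bound to a carbonyl carbon. The measured step touched the same saturated chain carbon bound to a carbonyl carbon, yet it exchanged one saturated amine for another, so it bears only loosely on an aromatic ring entering there. For compound 3 the expected step of a 1.8-fold higher number from compound 2 to compound 3 (0.25 log units; within the scatter) is small, leaning toward a higher number. Compound 3 is estimated at 250 nM, within 100 nM to 700 nM.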

Compound 3, half-maximal inhibitory concentration: 30 nM
Beside the measured number, compound 3's estimate is 8.3-fold (0.92 log units) above it, and the stated range ends above it.
By their numbers in this assay, from the lowest: compound 3; then compound 2; then compound 1.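

In this assay, an aromatic ring at this saturated chain carbon bound to a carbonyl carbon gives the lowest number of the three, with a 4.7-fold lower number from compound 2 to compound 3 (0.67 log units; beyond the scatter) and a 10-fold lower number from compound 1 to compound 3 (1.00 log units; beyond the scatter). The hydrogen-bond donor of piperazin-1-yl is therefore not needed for a low number here. No evidence accounts for the difference. Still open, as far as these compounds go, is whether the second ring nitrogen of 1H-imidazol-1-yl matters, which a pyrrol-1-yl or pyrazol-1-yl group could test. From the compounds shown here alone, a longer chain carrying the imidazole ring remains equally open.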